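This account rests on a few compounds, and the source may have more. Where it says the series, first, only, none or still open, it means among the compounds named here.

Compound 1 `CCOC(=O)/C=C1/C(=O)Nc2ccccc21` gives 77.7% in a functional assay on HL-60 cells (Homo sapiens) for inhibition, read by CCK-8 assay, with a stated time of 72 h, tested at 20 uM; a lower number here means less inhibition of growth, a higher number more inhibition of growth at the concentration tested.
Compound 2 `CC(C)(C)OC(=O)/C=C1/C(=O)Nc2ccccc21` gives 94.5% in this assay.
Compound 3 `CC(C)(C)OC(=O)/C=C1/C(=O)N(Cc2ccccc2)c2ccccc21` gives 91.7% in this assay.

Among these three numbers compound 2 stands highest. Compound 3 lies nearest to it, with a number 2.8 percentage points lower from compound 2 to compound 3 (within the scatter), a gap within the scatter, so the two cannot be ordered. Compound 1 lies furthest, with a number 16.8 percentage points higher from compound 1 to compound 2 (beyond the scatter), a gap beyond the scatter.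

Compound 4 `Cc1ccc2c(c1)/C(=C\C(=O)OC(C)(C)C)C(=O)N2` has not yet been measured in this assay. It differs from compound 2 in one place: methyl in place of hydrogen on an aromatic carbon. Neither of the two measured steps touches the aromatic ring. The step from compound 1 to compound 2 concerns the ester and was modest; the step from compound 2 to compound 3 concerns the amide nitrogen and stayed within the scatter. No measured step therefore bears directly on the change to compound 4, and the account rests on the observation that compound 2 and compound 3 both sit near the top of what this assay has shown.

He expects no step beyond the scatter: the step from compound 2 to compound 4 is estimated at a number 3.5 percentage points lower from compound 2 to compound 4 (within the scatter). For compound 4 he estimates 91%, with a range from 78% to 98%.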

Compound 4, percent growth inhibition at one concentration: 94.6%
Compound 4: the middle estimate sits 3.6 percentage points below what was measured, and the stated range covers the measured number.
By their numbers in this assay, from the lowest: compound 1; then compounds 3, 2 and 4 (each within the scatter of the next).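

A methyl group on an aromatic carbon is the first change shown on the six-membered aromatic ring of the shared core, and in this assay the result is a number 0.1 percentage points higher from compound 2 to compound 4 (within the scatter) so this carbon takes a methyl group with no step that can be told from the scatter. The ring thus joins the amide nitrogen as a place where a single change stayed within the scatter, while the change from ethyl to tert-butyl on the ester oxygen remains the only step shown beyond it. Nothing measured here offers an explanation for the number holding at this position.

With compound 2 and compound 4 both close to the top of the scale at a single concentration, this read-out leaves little room to show any further gain at this position, and it cannot separate the two. Also open, as far as these compounds go, is what a different group on this carbon would do, such as a methoxy group, a chlorine atom, an amine or a carboxylic acid, and whether a methyl group on the other ring carbons would give a similar number.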